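This account rests on a few compounds, and the source may have more. Where it says the series, first, only, none or still open, it means among the compounds named here.

Measured compounds in a functional assay for antagonist activity at thromboxane A2 receptor (Rattus norvegicus); on this read-out higher numbers stand for weaker binding and lower numbers for tighter binding:

compound 1, `CC(=O)NCc1ccccc1-c1ccc(COC2CC[C@H](N3CCCCCC3)[C@H]2OC/C=C\CCC(=O)O)cc1`, compound 1 gives 126 nM
compound 2, `O=C(O)CC/C=C\CO[C@H]1[C@@H](OCc2ccc(-c3ccc(CO)cc3)cc2)CC[C@@H]1N1CCCCCC1`, compound 2 gives 50.1 nM
compound 3, `O=C(O)CC/C=C\CO[C@@H]1[C@@H](OCc2ccc(-c3ccccc3)cc2)CC[C@@H]1N1CCCCC1`, compound 3 gives 1000 nM

Compound 1 holds the second highest of the three numbers in this assay. Its nearest neighbour is compound 2, which sits at a lower number, and the gap between them is beyond the usual scatter. Compound 3 is furthest away, at a higher number, again beyond the scatter. For the measured compounds named here, compound 2 and compound 3 each differ from compound 1 in more than one place, so no single-change step between the measured compounds can be read off.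

Compound 4, `NC(=O)Cc1ccccc1-c1ccc(COC2CC[C@H](N3CCCCCC3)[C@H]2OC/C=C\CCC(=O)O)cc1`, has not been measured. It differs from compound 1 in one place: carbamoyl in place of acetamido on a saturated chain carbon bound to an aromatic carbon. Going by the values given here, nothing among the measured compounds isolates this change. The group that leaves and the group that enters each carry one hydrogen-bond donor and one hydrogen-bond acceptor, and the change is a small one on the same chain, so a step from compound 1 to compound 4 within the scatter, in either direction, is what is expected: a 1.1-fold lower number from compound 1 to compound 4 (0.06 log units; within the scatter). Compound 4 is therefore estimated at 110 nM in this assay, with a plausible range from 40 nM to 320 nM.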

Compound 4, dissociation constant: 158 nM
Compound 4: middle estimate off by 1.4-fold (0.16 log units), on the low side; the range from low to high includes it.
By their numbers in this assay, from the lowest: compound 2; then compounds 1 and 4 (each within the scatter of the next); then compound 3.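

In this assay, for the compounds shown here, carbamoyl in place of acetamido on a saturated chain carbon bound to an aromatic carbon gives a 1.3-fold higher number from compound 1 to compound 4 (0.10 log units; within the scatter), the first single-change step that can be read. At this position, then, acetamidomethyl and carbamoylmethyl cannot be told apart on this read-out, so the acetamido group as a whole is not required to keep the number of compound 1. No measured data on hand account for this step or tie it to any property of either group.

On these data alone, whether the number stays within the scatter with a carboxylic acid, an amine or a nitrile at this place remains open. The step also rests on a single pair built on the core of compound 1, so its transfer to the core of compound 3 cannot be judged.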